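Shifting the chlorine on the thiourea phenyl ring

A few compounds are considered here, and "the series" means these few. Any claim that something is new, unique, unknown or untested is made for them only; others in the source may bear on it.

Three thiourea analogues sharing one core have been tested in a functional assay on the whole organism (strain Swiss albino) with Mus musculus as the target, in the maximal electroshock model, with a stated time of 0.5 h; on this read-out higher numbers stand for an effect only at larger amounts of compound and lower numbers for an effect already at smaller amounts. Compound 1 `COc1cc2c(cc1OC)C(=O)C(CC1CCN(C(=S)Nc3cccc([N+](=O)[O-])c3)CC1)C2` gives 300 mg/kg, compound 2 `COc1cc2c(cc1OC)C(=O)C(CC1CCN(C(=S)Nc3ccc([N+](=O)[O-])cc3)CC1)C2` gives 30 mg/kg, and compound 3 `COc1cc2c(cc1OC)C(=O)C(CC1CCN(C(=S)Nc3ccccc3Cl)CC1)C2` gives 100 mg/kg. Compound 3 thus stands second highest of the three numbers, with a 3.0-fold lower number from compound 1 to compound 3 (0.48 log units; beyond the scatter) and a 3.3-fold higher number from compound 2 to compound 3 (0.52 log units; beyond the scatter) placing it between the other two.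

Compound 4 `COc1cc2c(cc1OC)C(=O)C(CC1CCN(C(=S)Nc3ccc(Cl)cc3)CC1)C2` differs from compound 3 by 4-chlorophenyl in place of 2-chlorophenyl on an amide-type nitrogen. For the measured compounds named here, no measured pair exchanges 2-chlorophenyl for 4-chlorophenyl directly. The closest guide is the nitro series, where a 10-fold lower number from compound 1 to compound 2 (1.00 log units; beyond the scatter) shows that the 4-substituted phenyl needs less compound than its 3-substituted counterpart, and a 3.3-fold higher number from compound 2 to compound 3 (0.52 log units; beyond the scatter) shows the 4-nitrophenyl compound 2 ahead of the 2-chlorophenyl compound 3. Resting on these, a lower number is expected for compound 4, modest in size, so a 2.5-fold lower number from compound 3 to compound 4 (0.40 log units; beyond the scatter) is the estimated step. Compound 4 is therefore expected to give about 40 mg/kg, within a range from 15 mg/kg to 130 mg/kg.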

Compound 4, minimum effective dose: 30 mg/kg
Compound 4: the middle estimate sits 1.3-fold (0.12 log units) above what was measured; the measured number falls inside the stated range.
By their numbers in this assay, from the lowest: compounds 2 and 4 (each within the scatter of the next); then compound 3; then compound 1.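

Moving the chlorine, with the same atoms on the ring, is enough to shift the dose in this assay: the step is a 3.3-fold lower number from compound 3 to compound 4 (0.52 log units; beyond the scatter), so where the chlorine sits on this phenyl ring matters, not only which atoms are present. Chloro in place of nitro on an aromatic carbon gives no change at the digits printed from compound 2 to compound 4 (within the scatter), so 4-chlorophenyl and 4-nitrophenyl cannot be told apart here, while 4-chlorophenyl in place of 3-nitrophenyl gives a 10-fold lower number from compound 1 to compound 4 (1.00 log units; beyond the scatter). Nothing measured here explains these steps.

As far as these compounds go, it remains open how a phenyl ring carrying an amine or a carboxylic acid in place of the chlorine would behave. From the compounds shown here alone, a plain phenyl ring, or a longer chain on the amide-type nitrogen, is equally open.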